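The source may report more compounds than this note shows. Statements on the series, on what has been measured and on what is new or still open speak of the compounds shown alone.

In a functional assay (aorta) with Rattus norvegicus as the target (a lower number here means a stronger inhibitor, a higher number a weaker inhibitor), compound 1 `CC1(C)Oc2ccc(C#N)cc2[C@@H](/N=C(\NC#N)Nc2ccc([N+](=O)[O-])cc2)[C@@H]1O` gives 300 nM. Compound 2 `CC1(C)Oc2ccc(C#N)cc2[C@@H](/N=C(\NC#N)Nc2cccc(C(=O)O)c2)[C@@H]1O` gives > 100000 nM, which is a limit and not a number. Compound 3 `COc1ccc(N/C(=N/[C@@H]2c3cc(C#N)ccc3OC(C)(C)[C@H]2O)NC#N)cc1` has 4-methoxyphenyl in place of 3-carboxyphenyl on an amine nitrogen. Among the measured compounds shown here, one measured step bears on this change. That step, which brought in the same 3-carboxyphenyl in place of 4-nitrophenyl, was large: an at least 330-fold higher number from compound 1 to compound 2 (2.52 log units; beyond the scatter). For the measured compounds named here, with that step as the only guide, a large move to a lower number is expected in this assay once 3-carboxyphenyl leaves. The expected step is an at least 50-fold lower number from compound 2 to compound 3 (1.69 log units; beyond the scatter). For compound 3 the estimate is 2000 nM, with an expected range of 400 nM to 10000 nM.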

Compound 3, half-maximal inhibitory concentration: 32500 nM
Compound 3: the middle estimate sits 16-fold (1.21 log units) below what was measured; the whole stated range lies below it.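

In this assay, removing 3-carboxyphenyl from this amine nitrogen is not enough by itself: 4-methoxyphenyl in its place gives an at least 3.0-fold lower number from compound 2 to compound 3 (0.48 log units; beyond the scatter), while methoxy in place of nitro gives a 110-fold higher number from compound 1 to compound 3 (2.03 log units; beyond the scatter). The choice of group on the ring therefore still matters greatly once 3-carboxyphenyl has gone, with compound 1 and compound 3 lying far apart. The size of the step from compound 2 is only a bound because compound 2 has a limit and not a number: the limit of > 100000 nM in this assay, at which 1 of the 3 values shown sits.

Where plain phenyl, 4-chlorophenyl or 4-aminophenyl on this amine nitrogen would fall relative to compound 1 and compound 3 remains open.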